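Halogen exchange on the aryl ring of the dienone series

A few compounds are considered here, and "the series" means these few. Any claim that something is new, unique, unknown or untested is made for them only; others in the source may bear on it.

Measured so far:
compound 1, `CC1=C(/C=C/C(=O)/C=C/c2ccc(F)cc2)C(C)(C)CCC1`: 55800 nM
compound 2, `CC1=C(/C=C/C(=O)/C=C/c2ccccc2Cl)C(C)(C)CCC1`: 54200 nM

Going by the values given here, in a functional assay on Hep cells (Homo sapiens) for cytotoxicity, read by sulforhodamine B assay, with a stated time of 48 h (on this read-out lower numbers stand for stronger inhibition and higher numbers for weaker inhibition), compound 2 gives 54200 nM, the lowest of the two numbers so far; its nearest neighbour is compound 1 with 55800 nM, and a 1.0-fold lower number from compound 1 to compound 2 (0.01 log units; within the scatter) places that gap within the scatter, so no order between the two can be read from these data.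

Compound 3, `CC1=C(/C=C/C(=O)/C=C/c2ccccc2Br)C(C)(C)CCC1`, differs from compound 2 by bromo in place of chloro on an aromatic carbon; the aromatic position, ortho to a large group, is kept. Among the compounds with values here, the only measured step that bears on a change at this ring is a 1.0-fold lower number from compound 1 to compound 2 (0.01 log units; within the scatter), an exchange of one halogenated phenyl for another that left the number within the scatter. Within the data shown here, nothing so far separates one halogen on this ring from another. A step no larger than the scatter is therefore expected, a 1.0-fold lower number from compound 2 to compound 3 (0.02 log units; within the scatter), with no direction claimed.

On that basis compound 3 is estimated at 52000 nM in this assay, with a range from 26000 nM to 104000 nM.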

Compound 3, half-maximal inhibitory concentration: 16300 nM
Beside the measured number, compound 3's estimate is 3.2-fold (0.50 log units) above it; measured number below the stated range.
By their numbers in this assay, from the lowest: compound 3; then compounds 2 and 1 (each within the scatter of the next).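

In this assay, going by these compounds alone, the identity of the halogen on this aromatic carbon, ortho to a large group, turns out to count: bromo in place of chloro gives a 3.3-fold lower number from compound 2 to compound 3 (0.52 log units; beyond the scatter), the first step beyond the scatter. The 2-bromophenyl group also separates from 4-fluorophenyl, with a 3.4-fold lower number from compound 1 to compound 3 (0.53 log units; beyond the scatter), while compound 1 and compound 2 stay within the scatter of each other, so a halogenated phenyl as such does not set the number and the exchange to bromo is what moves it. No measurement shown gives a reason for this step.

The compounds shown hold only one bromo case, so it remains open whether the step continues to iodo or whether methyl or methoxy on the same aromatic carbon would give a number like that of compound 3. Going by these compounds, whether bromo acts the same way at another place on the ring also stays open, and so does the separate contribution of halogen and place in the 4-fluorophenyl to 2-bromophenyl change.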